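Pyridin-4-yl in place of the carbamoyl fluorophenyl group

The compounds below may be only part of what the source reports. "The series", "measured", "known", "first", "only" and "open" are said of these compounds alone.

Measured so far:
- compound 1 `CC(c1ccc2ncc(-c3ccc(F)cc3)cc2c1)n1nnc2ncc(-c3ccncc3)nc21`: 8.7 nM
- compound 2 `CC(c1cc2cc(-c3cnn(C)c3)cnc2cc1F)n1nnc2ncc(-c3ccc(C(N)=O)c(F)c3)nc21`: 0.9 nM
- compound 3 `CC(c1c(F)cc2ncc(-c3cnn(C)c3)cc2c1F)n1nnc2ncc(-c3ccc(C(N)=O)c(F)c3)nc21`: 0.4 nM

In a functional assay on NCI-H1993 cells (Homo sapiens) for inhibition, read by CCK-8 assay, with a stated time of 72 h (on this read-out lower numbers stand for stronger inhibition and higher numbers for weaker inhibition), compound 3 gives 0.4 nM, the lowest of the three numbers. Compound 2 comes nearest, and the step of a 2.3-fold lower number from compound 2 to compound 3 (0.35 log units; beyond the scatter) is modest yet beyond the scatter. Compound 1 lies furthest from compound 3.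

Compound 4 `CC(c1c(F)cc2ncc(-c3cnn(C)c3)cc2c1F)n1nnc2ncc(-c3ccncc3)nc21` differs from compound 3 by one change: pyridin-4-yl in place of 4-carbamoyl-3-fluorophenyl on an aromatic carbon. Among the measured compounds shown here, no measured pair isolates this change. For the measured compounds named here, the only compound that carries pyridin-4-yl is compound 1, and in this assay compound 1 gives 8.7 nM, but compound 1 also differs from compound 3 in the other aromatic group and in the fluorine pattern of the core, so its gap to compound 3 cannot be assigned to this change alone. Compounds 2 and 3 both carry the 4-carbamoyl-3-fluorophenyl group and both give the lowest numbers seen, so the change is expected to raise the number. For compound 4 the expected step is a 7.5-fold higher number from compound 3 to compound 4 (0.88 log units; beyond the scatter). Compound 4 is estimated at 3 nM, within a range from 0.8 nM to 12 nM.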

Compound 4, half-maximal inhibitory concentration: 0.2 nM
Estimate against measurement, compound 4: 15-fold (1.18 log units) above, and the stated range ends above it.
By their numbers in this assay, from the lowest: compounds 4 and 3 (each within the scatter of the next); then compound 2; then compound 1.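

In this assay, the step (a 2.0-fold lower number from compound 3 to compound 4 (0.30 log units; within the scatter)) shows that, on this aromatic carbon of the ring with two nitrogens, the 4-carbamoyl-3-fluorophenyl group can give way to the smaller pyridin-4-yl without a change that stands out from the scatter. Among the compounds shown here, until now this group had appeared only with the other aromatic group and core of compound 1, so this pair is the first to isolate the exchange, and it shows that neither the carbamoyl group nor the fluorine of the leaving group is required for a number this low on the core of compound 3. No measured evidence explains why the two groups read alike.

As far as these compounds go, it remains open whether the same exchange would read alike on the core of compound 2. Also open, from the compounds shown here alone, is what a plain phenyl, a pyridin-3-yl or a 4-carboxyphenyl group would give at this position.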